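Adding a methoxycarbonyl to a compound at the assay limit

The compounds below may be only part of what the source reports. "The series", "measured", "known", "first", "only" and "open" are said of these compounds alone.

Measured in an ADME assay on HEp-2 cells (Homo sapiens) for cytotoxicity, read by MTT assay, with a stated time of 72 h; a higher number here means a weaker inhibitor, a lower number a stronger inhibitor
Compound 1 `COc1ccc(C2=C(c3cc(OC)c(OC)c(OC)c3)C(=O)CC2O[SiH2]C(C)(C)C)cc1` gives > 100 ug/mL
Compound 2 `C=CCOc1cc(C2=C(c3cc(OC)c(OC)c(OC)c3)C(=O)C(O)C2)ccc1OC` gives > 100 ug/mL
Compound 3 `COc1cc(C2=C(c3cc(C)c(OC)c(C)c3)C(OC(C)=O)CC2=O)cc(OC)c1OC` gives > 100 ug/mL

Compound 1 stands at > 100 ug/mL as a limit, not a number. The same holds for compound 2 and compound 3, so the whole picture so far is the limit of > 100 ug/mL in this assay, at which 3 of the 3 values shown sit, and nothing more.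

Compound 4 `COC(=O)c1cc(C2=C(c3cc(OC)c(OC)c(OC)c3)C(=O)CC2O[SiH2]C(C)(C)C)ccc1OC` keeps the core of compound 1 and differs from it in one place. The change is methoxycarbonyl in place of hydrogen on an aromatic carbon and it puts a methoxycarbonyl in place of hydrogen on an aromatic carbon, ortho to a methoxy group and meta to a large group. Put another way, 4-methoxyphenyl becomes 4-methoxy-3-(methoxycarbonyl)phenyl.

Within the data shown here, no pair of measured compounds shows a step, so this assay offers no guide to the size of this change. No step beyond the scatter is expected, in either direction. That expectation rests on compound 1 and its limit of > 100 ug/mL as the only starting point. The expected step is a number no higher from compound 1 to compound 4 (the limit leaves the size open) and the assay may well report only a limit again. Compound 4 is estimated at 100 ug/mL with an expected range from 50 ug/mL to 200 ug/mL as the likely outcome.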

Compound 4, half-maximal inhibitory concentration: > 100 ug/mL
Compound 4: no number, only a limit (the forecaster's own chance of this, stated with the estimate: 70%); the middle value sits exactly at the limit.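

Compound 4 gives > 100 ug/mL, which is a limit and not a number. Compound 1 also stands at a limit, so no step can be read from compound 1 to compound 4. The picture stays the same: the limit of > 100 ug/mL in this assay, at which 4 of the 4 values shown sit. From the compounds shown here alone, whether adding the methoxycarbonyl changes the real value of compound 1 at all remains open.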